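Replacing one ring of compound 1 with cyclopropyl

The compounds below may be only part of what the source reports. "The series", "measured", "known", "first", "only" and "open" are said of these compounds alone.

In a functional assay on HCT-116 cells (Homo sapiens) for inhibition, read by MTT assay, with a stated time of 72 h (a lower number here means a stronger inhibitor of growth, a higher number a weaker inhibitor of growth), compound 1 `COc1ccc(-c2nc3c(N4CCN(Cc5cc(C)on5)CC4)c(Br)cnc3[nH]2)cc1` gives 540 nM. Compound 2 `Cc1cc(CN2CCN(c3c(Cl)cnc4[nH]c(-c5ccc(CN)cc5)nc34)CC2)no1` gives 650 nM, within the scatter of that number, while compound 3 `Cc1cc(CN2CCN(c3c(Br)cnc4[nH]c(N5CCN(Cn6cccn6)CC5)nc34)CC2)no1` stands apart at 120 nM, a stronger result beyond the scatter.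

Compound 4 `COc1ccc(-c2nc3c(N4CCN(CC5CC5)CC4)c(Br)cnc3[nH]2)cc1` keeps the core of compound 1 but has cyclopropyl in place of 5-methyl-1,2-oxazol-3-yl on a saturated chain carbon bound to an amine nitrogen in a ring. Among the compounds with values here, all three measured compounds carry the 5-methyl-1,2-oxazol-3-yl group, so no measured pair shows this change.

A small step toward weaker growth inhibition in this assay is expected, probably within the scatter: the estimated step is a 1.5-fold higher number from compound 1 to compound 4 (0.17 log units; within the scatter). Compound 4 is estimated at 800 nM, with an expected range of 250 nM to 2500 nM.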

Compound 4, concentration for 50% growth inhibition: 830 nM
Compound 4: middle estimate off by 1.0-fold (0.02 log units), on the low side; the range from low to high includes it.
By their numbers in this assay, from the lowest: compound 3; then compounds 1, 2 and 4 (each within the scatter of the next).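

In this assay, within the data shown here, the one pair that differs only at this place gives a 1.5-fold higher number from compound 1 to compound 4 (0.19 log units; within the scatter) and so gives the first direct reading of this change. On a saturated chain carbon bound to an amine nitrogen in a ring, the five-membered aromatic ring can be replaced by cyclopropyl, a ring of carbon only with no hydrogen-bond acceptors, without a change beyond the scatter. No measurement shown here offers a reason for this result.

Open, from the compounds shown here alone, is whether an amine or a carboxylic acid on a longer chain at this place would also stay within the scatter. Also open, going by these compounds, is whether cyclopropyl would behave the same way on compound 3.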